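Adding a Second Chloro to Compound 2

The compounds below may be only part of what the source reports. "The series", "measured", "known", "first", "only" and "open" are said of these compounds alone.

Compound 2 `Cn1nnnc1SCC(=O)N/N=C/c1ccc(Cl)cc1` gives 2100000 nM in an ADME assay on NIH3T3 cells (Mus musculus) for cytotoxicity, read by XTT assay, with a stated time of 24 h; on this read-out lower numbers stand for stronger inhibition and higher numbers for weaker inhibition. Of the three measured compounds it stands second highest: compound 3 `CC(C)c1ccc(/C=N/NC(=O)CSc2nnnn2C)cc1` gives 1200000 nM, and a 1.8-fold lower number from compound 2 to compound 3 (0.24 log units; within the scatter), whereas compound 1 `Cn1nnnc1SCC(=O)N/N=C/c1ccc([N+](=O)[O-])cc1` gives 9300000 nM, with a 4.4-fold lower number from compound 1 to compound 2 (0.65 log units; beyond the scatter) and a 7.8-fold lower number from compound 1 to compound 3 (0.89 log units; beyond the scatter). Compound 4 `Cn1nnnc1SCC(=O)N/N=C/c1ccc(Cl)cc1Cl` differs from compound 2 by chloro in place of hydrogen on an aromatic carbon. Going by the values given here, none of the measured steps adds a group where only hydrogen stood before; they exchange the group already present, and the two steps beyond the scatter both moved toward lower numbers. One therefore expects in this assay a small step toward a lower number, a 1.5-fold lower number from compound 2 to compound 4 (0.18 log units; within the scatter), which may not clear the scatter. Compound 4 is estimated at 1400000 nM, within a range from 500000 nM to 4000000 nM.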

Compound 4, half-maximal inhibitory concentration: 2140000 nM
Estimate against measurement, compound 4: 1.5-fold (0.18 log units) below; the range from low to high includes it.
By their numbers in this assay, from the lowest: compounds 3, 2 and 4 (each within the scatter of the next); then compound 1.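

In this assay, chloro in place of hydrogen, ortho to a large group and meta to a chloro group, gives a 1.0-fold higher number from compound 2 to compound 4 (0.01 log units; within the scatter), so the two numbers stay within the scatter of each other. Unlike the earlier steps, which exchanged one group for another, this one adds a group where only hydrogen stood, and at this position the added chloro leaves the read-out unresolved from that of compound 2. Nothing measured here offers a reason for this result. The compounds shown leave open whether an amine or a methoxy group at this same position would also stay within the scatter of compound 2.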